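The compounds below may be only part of what the source reports. "The series", "measured", "known", "first", "only" and "open" are said of these compounds alone.

Compound 3 `O=C(Nc1ccc(Oc2ccnc3[nH]ccc23)c(F)c1)c1cc2cccnc2n(-c2ccccc2)c1=O` is the one with a fluoro on the ring that carries the amide nitrogen, and in a functional assay on A549 cells (Homo sapiens) for antiproliferative activity, read by MTT assay, with a stated time of 72 h (on this read-out lower numbers stand for stronger inhibition and higher numbers for weaker inhibition), compound 3 gives 190 nM. That is the lowest of the three numbers seen so far. Its nearest neighbour is compound 1 `O=C(Nc1ccc(Oc2ccnc3[nH]ccc23)cc1)c1cc2cccnc2n(-c2ccccc2)c1=O`, which in this assay gives 360 nM; the step of a 1.9-fold lower number from compound 1 to compound 3 (0.28 log units; within the scatter) is one that repeated measurements could produce on their own, so the two cannot be ranked against each other. Further away stands compound 2 `O=C(Nc1ccc(Oc2ccnc3[nH]ccc23)cc1)c1cc2cccnc2n(-c2ccc(Br)cc2F)c1=O`, which in this assay gives 1570 nM.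

Compound 4 `O=C(Nc1ccc(Oc2ccnc3[nH]ccc23)c(F)c1)c1cc2cccnc2n(-c2ccc(Cl)cc2)c1=O` differs from compound 3 in one place: chloro in place of hydrogen on an aromatic carbon. The change sits on the ring attached to the aromatic nitrogen of the shared core, para to a large group. Going by the values given here, only one measured step touches that ring, namely a 4.4-fold higher number from compound 1 to compound 2 (0.64 log units; beyond the scatter), and that step brought in a bromo and a fluoro together. Because a 4.4-fold higher number from compound 1 to compound 2 (0.64 log units; beyond the scatter) was a modest rise for a double substitution, a single chloro is expected to move the number in the same direction but by less, close to the edge of the scatter. Compound 4 is therefore estimated at 380 nM, with a range from 160 nM to 900 nM, which corresponds to an expected step of a 2.0-fold higher number from compound 3 to compound 4 (0.30 log units; within the scatter).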

Compound 4, half-maximal inhibitory concentration: 110 nM
Beside the measured number, compound 4's estimate is 3.5-fold (0.54 log units) above it; the measured number lies below the stated range.
By their numbers in this assay, from the lowest: compounds 4, 3 and 1 (each within the scatter of the next, the first and the last beyond it); then compound 2.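

In this assay a chloro placed para to a large group does not shift the number measurably, since a 1.7-fold lower number from compound 3 to compound 4 (0.24 log units; within the scatter) is a step that repeated measurements could produce on their own. Going by these compounds alone, this is new, as the only earlier step on the ring attached to the aromatic nitrogen of the shared core, a 4.4-fold higher number from compound 1 to compound 2 (0.64 log units; beyond the scatter), brought in a bromo and a fluoro together and lay beyond the scatter, so it could not show that this place accepts a single halogen without a clear rise in the number, as compound 4 now does. Nothing shown gives a measured reason why this place accepts the chloro.

Going by these compounds, whether the rise seen with compound 2 comes from its bromo, its fluoro or the two together stays open, as does whether the chloro would behave the same way on compound 1, which has no fluoro on the ring that carries the amide nitrogen. The compounds shown also leave open how this place responds to a different kind of group, such as a methoxy, an amine or a carboxylic acid.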